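This account rests on a few compounds, and the source may have more. Where it says the series, first, only, none or still open, it means among the compounds named here.

Measured so far in a functional assay on NCI-H226 cells (Homo sapiens) for inhibition, read by sulforhodamine B assay, with a stated time of 48 h, tested at 10 uM; on this read-out higher numbers stand for more inhibition of growth at the one concentration tested and lower numbers for less inhibition of growth:
- compound 1 `C/C(=N/O)c1ccc(NC(=O)Cn2nc(C(F)(F)F)nc2N)cc1`: 12.9%
- compound 2 `COc1cc(-c2nc3sc(-c4ccccc4)cn3n2)cc(OC)c1OC`: 23%

Compound 1, at 12.9%, holds the lower of the two numbers. Compound 2, at 23%, lies above it by more than the usual scatter. Going by the values given here, these two compounds do not differ in just one place, so the gap between them gives no measured size for a single change, and the series offers no such step to scale from.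

Next in line is compound 3 `C/C(=N/O)c1ccc(NC(=O)Cn2nc(-c3ccccc3)nc2N)cc1`, which keeps the rest of compound 1 and changes one group: phenyl in place of trifluoromethyl on an aromatic carbon. In words, this is phenyl in place of trifluoromethyl on an aromatic carbon. Among the compounds with values here, with no precedent for this change, the expectation in this assay is weak. With compound 1 at 12.9%, the number has limited room to fall, so a small upward move is slightly favoured over a downward one, and no move beyond the scatter is the likeliest outcome. The estimated step is a number 5.1 percentage points higher from compound 1 to compound 3 (within the scatter). For compound 3 the expected value is 18%, with an estimated range from 5% to 35%.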

Compound 3, percent growth inhibition at one concentration: 3.91%
The estimate for compound 3 lay 14.1 percentage points above the measured number; measured number outside the range, below it.
By their numbers in this assay, from the lowest: compounds 3 and 1 (each within the scatter of the next); then compound 2.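

In this assay, the series now has its first step in a single place: phenyl in place of trifluoromethyl on an aromatic carbon, between two ring nitrogen atoms, gives a number 9 percentage points lower from compound 1 to compound 3 (within the scatter). At this position, a group of 4 heavy atoms with no ring and a group of 6 heavy atoms with one six-membered aromatic ring of carbon only therefore cannot be told apart on this read-out. This single pair gives no sign that this exchange at this position separates the two compounds at the one concentration tested, and no accompanying measurement bears on why they read alike.

The compounds shown leave open whether a smaller group such as methyl, or a group carrying an amine or a carboxylic acid, at this same carbon would give a number beyond the scatter from compound 1. They also leave open whether a substituted phenyl at this position, or a change at the oxime or the amide linker of the shared core, would separate from compound 3 on this read-out.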